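The compounds below may be only part of what the source reports. "The series", "measured", "known", "first", "only" and "open" are said of these compounds alone.

Measured so far:
- compound 1, `O=C([C@@H]1C[C@H](N2CCCN(c3ccc([N+](=O)[O-])cc3)CC2)CN1)N1CCSC1`, 2.9 nM
- compound 2, `N#Cc1cccnc1N1CCN([C@@H]2CN[C@H](C(=O)N3CCSC3)C2)CC1`, 1.2 nM
- compound 3, `O=C([C@@H]1C[C@H](N2CCC(c3ccccc3)CC2)CN1)N1CCSC1`, 9.6 nM

Of the compounds shown here, three sharing one core have been tested in an assay on a cell-free system (plasma) for inhibition of Dipeptidyl peptidase 4 (Rattus norvegicus), read by fluorescence; a lower number here means a stronger inhibitor, a higher number a weaker inhibitor. Compound 2 gives 1.2 nM, the lowest of the three numbers. Its nearest neighbour is compound 1, which gives 2.9 nM, a gap described as beyond the scatter, and the furthest is compound 3 at 9.6 nM, also beyond the scatter. All three therefore sit within a fairly narrow band of strong inhibition.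

Compound 4, `N#Cc1ccnc(N2CCN([C@@H]3CN[C@H](C(=O)N4CCSC4)C3)CC2)c1`, has not yet been measured in this assay. It differs from compound 2 only in how the same atoms are joined: 4-cyanopyridin-2-yl in place of 3-cyanopyridin-2-yl on an amine nitrogen in a ring. Among the measured compounds shown here, no measured pair isolates this kind of change, so nothing in the data fixes its size or direction. The author expects a small step, likely toward a higher number, and quite possibly one that does not rise above the scatter. The estimate for compound 4 is 3 nM, with a range from 0.8 nM to 12 nM, which would mean an expected step of a 2.5-fold higher number from compound 2 to compound 4 (0.40 log units; beyond the scatter).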

Compound 4, half-maximal inhibitory concentration: 1.9 nM
Compound 4: middle estimate off by 1.6-fold (0.20 log units), on the high side; the range from low to high includes it.
By their numbers in this assay, from the lowest: compounds 2, 4 and 1 (each within the scatter of the next, the first and the last beyond it); then compound 3.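

In this assay, 4-cyanopyridin-2-yl in place of 3-cyanopyridin-2-yl on an amine nitrogen in a ring gives a 1.6-fold higher number from compound 2 to compound 4 (0.20 log units; within the scatter), so this assay does not separate the two groups at this place. The earlier compounds shown here differ from one another in more than one place, and none of them could show what this change alone does. Nothing available here bears on why the two groups read alike.

Still open is whether the nitrile itself matters at this place, since both groups carry one and the compounds shown do not tell how a carboxylic acid or an amide in its stead would read in this assay. They also leave open how a plain phenyl on the same ring nitrogen would compare with either pyridine group.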